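The source may report more compounds than this note shows. Statements on the series, on what has been measured and on what is new or still open speak of the compounds shown alone.

Two compounds have values in a functional assay on the whole organism (strain Sprague-Dawley) for inhibition, with Rattus norvegicus as the target, with a stated time of 10 min (on this read-out lower numbers stand for an effect already at smaller amounts and higher numbers for an effect only at larger amounts of compound), so far.

Compound 1 `CCOc1ccc(C(=O)O)cc1-c1ncc(C(=O)O)c(=O)[nH]1` gives 25 mg/kg
Compound 2 `CCOc1ccc(N)cc1-c1ncc(C(=O)O)c(=O)[nH]1` gives 1.2 mg/kg

Compound 2 holds the lower of these two numbers. Within the data shown here, the one measured step is a 21-fold lower number from compound 1 to compound 2 (1.32 log units; beyond the scatter) and it is large. It shows that the group on this aromatic carbon can matter, but it does not test dimethylamino. Compound 3 `CCOc1ccc(N(C)C)cc1-c1ncc(C(=O)O)c(=O)[nH]1` has dimethylamino in place of amino on an aromatic carbon, counted as dimethylamino in place of amino on an aromatic carbon in full. A much smaller step towards a higher number is therefore expected in this assay and may stay within the scatter. The expected step is a 1.7-fold higher number from compound 2 to compound 3 (0.22 log units; within the scatter) on this estimate. Compound 3 is estimated at 2 mg/kg with an expected range from 0.5 mg/kg to 8 mg/kg here.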

Compound 3, dose for 50% inhibition: 0.3 mg/kg
Beside the measured number, compound 3's estimate is 6.7-fold (0.82 log units) above it; the measured number lies below the stated range.
By their numbers in this assay, from the lowest: compound 3; then compound 2; then compound 1.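

In this assay, dimethylamino in place of amino gives a 4.0-fold lower number from compound 2 to compound 3 (0.60 log units; beyond the scatter), so this position still responds to a change between two amines, and the hydrogen-bond donors counted on amino are not needed for the effect. Dimethylamino in place of carboxy gives an 83-fold lower number from compound 1 to compound 3 (1.92 log units; beyond the scatter), a larger step than amino gave in place of carboxy. Nothing available explains either step.

From the compounds shown here alone, whether methylamino would fall between amino and dimethylamino remains open. So does whether diethylamino or pyrrolidine would extend the trend or reverse it.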